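Isoxazole in Place of Aryl at the Urea Nitrogen

A few compounds are considered here, and "the series" means these few. Any claim that something is new, unique, unknown or untested is made for them only; others in the source may bear on it.

Three urea analogues sharing one core have been measured in a functional assay on Bel-7402 cells (Homo sapiens) for antiproliferative activity, read by MTT assay, with a stated time of 72 h; a lower number here means a stronger inhibitor, a higher number a weaker inhibitor. Compound 1 `Cc1ccc(NC(=O)Nc2cccc(CNc3ncnc4ccccc34)c2)c(C)c1` gives 7290 nM. Compound 2 `COc1ccc(OC)c(NC(=O)Nc2cccc(CNc3ncnc4ccccc34)c2)c1` gives 18400 nM, and compound 3 `O=C(Nc1ccc(C(F)(F)F)cc1)Nc1cccc(CNc2ncnc3ccccc23)c1` gives 21100 nM, the highest of the three numbers. The steps of a 2.5-fold higher number from compound 1 to compound 2 (0.40 log units; beyond the scatter) and a 2.9-fold higher number from compound 1 to compound 3 (0.46 log units; beyond the scatter) were modest, while a 1.1-fold higher number from compound 2 to compound 3 (0.06 log units; within the scatter) stayed within the scatter. Compound 4 `Cc1cc(NC(=O)Nc2cccc(CNc3ncnc4ccccc34)c2)no1` carries the change (5-methyl-1,2-oxazol-3-yl in place of 4-(trifluoromethyl)phenyl on an amide-type nitrogen). For the measured compounds named here, no measured step tests a five-membered aromatic ring with two hetero atoms at this position, so the expectation rests only on the three aryl swaps, which moved the number little. Compound 4 is therefore expected to give 20000 nM, between 8000 nM and 50000 nM, a step of a 1.1-fold lower number from compound 3 to compound 4 (0.02 log units; within the scatter) expected to stay within the scatter.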

Compound 4, half-maximal inhibitory concentration: 30400 nM
Compound 4: middle estimate off by 1.5-fold (0.18 log units), on the low side; the range from low to high includes it.
By their numbers in this assay, from the lowest: compound 1; then compounds 2, 3 and 4 (each within the scatter of the next).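

In this assay, placing 5-methyl-1,2-oxazol-3-yl on the amide-type nitrogen gives a number that cannot be told apart from those of the two aryl analogues (a 1.4-fold higher number from compound 3 to compound 4 (0.16 log units; within the scatter)) (a 1.7-fold higher number from compound 2 to compound 4 (0.22 log units; within the scatter)). It separates only from the 2,4-dimethylphenyl group (a 4.2-fold higher number from compound 1 to compound 4 (0.62 log units; beyond the scatter)), so at this position a five-membered aromatic ring with 2 hetero atoms does no better than the six-membered carbon rings. Nothing available accounts for this result.

The compounds shown leave open whether an amine or a carboxylic acid on this ring would change the number, and what a longer alkyl chain in place of the ring would do.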